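Removing the carbamoylamino link: an estimate for compound 4

A few compounds are considered here, and "the series" means these few. Any claim that something is new, unique, unknown or untested is made for them only; others in the source may bear on it.

Measured so far, in a functional assay on MCF7 cells (Homo sapiens) for inhibition, read by MTT assay, with a stated time of 72 h; a lower number here means a stronger inhibitor, a higher number a weaker inhibitor:
Compound 1, `COc1cc(NC(C)CCCNC(=O)NNC(=O)Nc2ccc(Br)cc2)c2ncccc2c1`, gives 100 nM.
Compound 2, `COc1cc(NC(C)CCCNC(=O)Nc2ccc(C(F)(F)F)cc2)c2ncccc2c1`, gives 1900 nM.
Compound 3, `COc1cc(NC(C)CCCNC(=O)NNC(=O)Nc2ccc(O)cc2)c2ncccc2c1`, gives 2600 nM.

Compound 3 has the highest number of the three. Its nearest neighbour is compound 2, a 1.4-fold higher number from compound 2 to compound 3 (0.14 log units; within the scatter), which falls within the scatter, so the two cannot be told apart. Its furthest is compound 1, a 26-fold higher number from compound 1 to compound 3 (1.41 log units; beyond the scatter).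

Compound 4, `COc1cc(NC(C)CCCNC(=O)Nc2cccc(O)c2)c2ncccc2c1`, differs from compound 3 in one place: 3-hydroxyphenyl in place of ((4-hydroxyphenyl)carbamoyl)amino on an amide-type nitrogen. The closest measured step is the change from compound 2 to compound 3, where the longer linker entered beside a different ring group and the number barely moved: a 1.4-fold higher number from compound 2 to compound 3 (0.14 log units; within the scatter). The large step from compound 1 to compound 2, a 19-fold higher number from compound 1 to compound 2 (1.28 log units; beyond the scatter), involved the same kind of linker loss but also a change of ring group, so it does not separate the two effects. In compound 4 the hydroxy group stays. The step to compound 4 in this assay is therefore expected to be small, a 1.0-fold lower number from compound 3 to compound 4 (0.02 log units; within the scatter), with no clear direction. Compound 4 is estimated at 2500 nM, within 800 nM to 8000 nM.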

Compound 4, half-maximal inhibitory concentration: 11000 nM
Compound 4: middle estimate off by 4.4-fold (0.64 log units), on the low side, and the stated range ends below it.
By their numbers in this assay, from the lowest: compound 1; then compounds 2 and 3 (each within the scatter of the next); then compound 4.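

In this assay, putting 3-hydroxyphenyl in place of ((4-hydroxyphenyl)carbamoyl)amino on the amide-type nitrogen is not a neutral swap (a 4.2-fold higher number from compound 3 to compound 4 (0.63 log units; beyond the scatter)). Compounds 2 and 3 could not be told apart, yet compound 4 separates from 4-(trifluoromethyl)phenyl at this nitrogen (a 5.8-fold higher number from compound 2 to compound 4 (0.76 log units; beyond the scatter)) and lies very far from the bromo compound (a 110-fold higher number from compound 1 to compound 4 (2.04 log units; beyond the scatter)), so compound 4 has the highest number of the four. No other kind of measurement is available to explain this rise.

On these data alone, the step to compound 4 removes the carbamoylamino link and also changes 4-hydroxyphenyl to 3-hydroxyphenyl, so the share of each change stays unknown. As far as these compounds go, how the urea-type chain would respond to an amine or a carboxylic acid on the ring in place of hydroxy also remains open.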